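Fluoro for methyl: from compound 3 to compound 4

The source may hold more compounds than are shown below. What is called first, only, known or untested is meant among the compounds shown, and "the series" means these compounds.

Compound 1 `Cc1ccc(NC(=O)C(=O)NC(c2nc(C)c(CO)s2)C2CCCCN2)c(F)c1`: > 109000 nM (a limit)
Compound 2 `Cc1nc(C(NC(=O)C(=O)Nc2ccc(Cl)c(F)c2)C2CCCCN2)sc1CO`: 77800 nM
Compound 3 `Cc1ccc(NC(=O)C(=O)NC(c2nc(C)c(CO)s2)C2CCCCN2)cc1F`: > 88000 nM (a limit)

These values come from an ADME assay on MT2 cells (Homo sapiens) for cytotoxicity, read by XTT assay, with a stated time of 4 days; a lower number here means that less compound is tolerated, a higher number that more compound is tolerated. Compound 3 has only a limit there, > 88000 nM, and not a number. Compound 4 `Cc1nc(C(NC(=O)C(=O)Nc2ccc(F)c(F)c2)C2CCCCN2)sc1CO` carries fluoro in place of methyl on an aromatic carbon, ortho to a fluoro group and para to a large group (fluoro in place of methyl on an aromatic carbon). Going by the values given here, two measured steps bear on this change. Methyl in place of chloro gave an at least 1.1-fold higher number from compound 2 to compound 3 (0.05 log units; that floor lies within the scatter). The swap of 2-fluoro-4-methylphenyl for 4-chloro-3-fluorophenyl gave an at least 1.4-fold lower number from compound 1 to compound 2 (0.14 log units; that floor lies within the scatter). Both floors lie within the scatter, so no step beyond the scatter is expected in this assay. The expected step is a step that the limit leaves unreadable from compound 3 to compound 4. Compound 4 is estimated at 90000 nM, with an expected range of 50000 nM to 140000 nM.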

Compound 4, half-maximal cytotoxic concentration: > 87000 nM
Compound 4 was reported as a limit (the forecaster's own chance of this, stated with the estimate: 50%); the middle value does not contradict the limit.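

In this assay compound 4 gives > 87000 nM, which is a limit and not a number. Fluoro at this position therefore also ends in a limit, as methyl does in compound 3, while the swap from chloro gives an at least 1.1-fold higher number from compound 2 to compound 4 (0.04 log units; that floor lies within the scatter). The steps linking compound 4 to compound 3 and to compound 1 join two limits and cannot be read.

As far as these compounds go, the true number for compound 4 stays open. So does how a methoxy or trifluoromethyl group at this position would read in this assay.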